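Swapping the Piperidine Arm for an Oxopiperazine

This account rests on a few compounds, and the source may have more. Where it says the series, first, only, none or still open, it means among the compounds named here.

Compound 1 `CC(C)N1CCC(c2ccc3c(c2)oc(=O)n3C(=O)NCCCCc2ccccc2)CC1` is the lowest of the three compounds measured in a physicochemical assay for solubility, read by HPLC, in phosphate buffer, measured as kinetic solubility, with a stated time of 1 h, at pH 7.4, tested at 250 uM (on this read-out higher numbers stand for higher solubility and lower numbers for lower solubility), where compound 1 gives 50000 nM. Compound 2 `CN1CCC(c2cc3oc(=O)n(C(=O)NCCCCc4ccccc4)c3cc2F)CC1` lies within the scatter, as compound 2 gives 70000 nM, while compound 3 `CC(C)CNC(=O)n1c(=O)oc2cc(C3CCN(C)CC3)ccc21` is beyond it, since compound 3 gives 240000 nM. Compound 4 `CN1CCN(c2ccc3c(c2)oc(=O)n3C(=O)NCCCCc2ccccc2)CC1=O` is not yet measured. It differs from compound 1 by 4-methyl-3-oxopiperazin-1-yl in place of 1-isopropylpiperidin-4-yl on an aromatic carbon. Going by the values given here, no step between measured compounds mirrors this change, so nothing measured here anchors its direction. The account expects at most a modest move, likely downward, with the step from compound 1 to compound 4 estimated as a 1.7-fold lower number from compound 1 to compound 4 (0.22 log units; within the scatter). Compound 4 is therefore expected to give about 30000 nM in this assay, within a range of 10000 nM to 100000 nM.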

Compound 4, solubility: < 1000 nM
Compound 4 gave a limit, no number (the forecaster's own chance of this, stated with the estimate: 10%); middle value at least 30-fold (1.47 log units) from the limit.
By their numbers in this assay, from the lowest: compounds 1 and 2 (each within the scatter of the next); then compound 3. At a limit, below all of these: compound 4.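

The aromatic carbon that carries 1-isopropylpiperidin-4-yl in compound 1 proves sensitive to what stands on it in this assay: with 4-methyl-3-oxopiperazin-1-yl in its place, the result is an at least 50-fold lower number from compound 1 to compound 4 (1.69 log units; beyond the scatter). In this assay compound 4 stands at a limit, < 1000 nM, and not at a number. This step is therefore a bound and not a measured size: the limit of < 1000 nM in this assay, at which 1 of the 4 values shown sits.

The carbonyl and the second ring nitrogen enter together, and the compounds shown do not separate them. Also open, on these data alone, is how a 4-methylpiperazin-1-yl group, which lacks the carbonyl, or a morpholin-4-yl group would read on this carbon.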